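Leaving the 4-methylpiperazin-1-yl group of compound 2

The compounds below may be only part of what the source reports. "The series", "measured", "known", "first", "only" and "open" are said of these compounds alone.

Of the compounds shown here, two on the shared core have been read so far in an ADME assay on microsomes from liver (Mus musculus) for metabolic stability, read by LC-MS, using NADPH, with stated times of 15 min and 60 min, tested at 4.6 uM; on this read-out higher numbers stand for a longer-lived compound and lower numbers for a shorter-lived compound. Compound 1 `CN1CCC(c2ccc3c(c2)oc(=O)n3C(=O)NCCCCc2ccccc2)CC1=O` gives 0.583 h. Compound 2 `CN1CCN(c2ccc3c(c2)oc(=O)n3C(=O)NCCCCc2ccccc2)CC1` gives < 0.0834 h, which is a limit of the assay and not a number. Among the compounds with values here, the only evidence on where compound 2 stands is the limit of < 0.0834 h in this assay, at which 1 of the 2 values shown sits.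

Compound 3 `CN1CCC(c2ccc3c(c2)oc(=O)n3C(=O)NCCCCc2ccccc2)CC1` has 1-methylpiperidin-4-yl in place of the 4-methylpiperazin-1-yl of compound 2 on the same aromatic carbon: 1-methylpiperidin-4-yl in place of 4-methylpiperazin-1-yl on an aromatic carbon. Within the data shown here, one measured step bears on this change, an at least 6.9-fold lower number from compound 1 to compound 2 (0.84 log units; beyond the scatter), which lies beyond the scatter and brought in the group that compound 3 gives up. That step sets the scale, although it involved a different group from the one entering here. A move to a higher number in this assay is therefore expected, recovering only part of that size. The expected step is an at least 2.9-fold higher number from compound 2 to compound 3 (0.47 log units; beyond the scatter). In this assay the estimate for compound 3 is 0.25 h, with an expected range from 0.09 h to 0.6 h.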

Compound 3, half-life: 0.667 h
Beside the measured number, compound 3's estimate is 2.7-fold (0.43 log units) below it; the whole stated range lies below it.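

In this assay, 1-methylpiperidin-4-yl in place of 4-methylpiperazin-1-yl on the aromatic carbon gives an at least 7.9-fold higher number from compound 2 to compound 3 (0.90 log units; beyond the scatter), so a single ring atom separates the two groups at this position and the read-out responds strongly to that change. The size of this step is only a bound, since the value of compound 2 is a limit of the assay and not a number: the limit of < 0.0834 h in this assay, at which 1 of the 3 values shown sits.

Set against 1-methyl-2-oxopiperidin-4-yl, the same group gives a 1.1-fold higher number from compound 1 to compound 3 (0.06 log units; within the scatter), so the ring carbonyl leaves no difference that can be read, and among the three groups shown only 4-methylpiperazin-1-yl stands apart.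

Still open, on these data alone, is whether the short half-life goes with the second ring nitrogen as such, with the ring's attachment through nitrogen to the aromatic carbon, or with the methyl on that nitrogen. Piperidin-1-yl, morpholin-4-yl and an unmethylated piperazin-1-yl on the same carbon would pull these apart, and a true number for compound 2 would be needed to size the effect.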